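The source may hold more compounds than are shown below. What is called first, only, known or untested is meant among the compounds shown, and "the series" means these compounds.

Compound 3 `O=C(/C=C1\CCc2ccc(F)cc21)N1CCC1` gives 14% in a functional assay on the whole organism with Rattus norvegicus as the target, at a dose of 20 mg/kg by the oral route (on this read-out lower numbers stand for less inhibition and higher numbers for more inhibition at the one dose given (going by the name of the read-out)), the lowest of the three numbers in hand. Its neighbours are compound 2 `CCN(C)C(=O)/C=C1\CCc2ccc(F)cc21`, which gives 20%, and compound 1 `CCNC(=O)/C=C1\CCc2ccc(F)cc21`, which gives 45%; the step of a number 6 percentage points lower from compound 2 to compound 3 (within the scatter) lies within the scatter, while the step of a number 31 percentage points lower from compound 1 to compound 3 (beyond the scatter) lies beyond it.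

Compound 4 `O=C(/C=C1\CCc2ccc(F)cc21)NC1CC1` differs from compound 3 in one place: cyclopropylamino in place of azetidin-1-yl on a carbonyl carbon. Going by the values given here, two measured steps bear on this change. Compound 1 carries an ethylamino group, also with one hydrogen-bond donor, and the step of a number 31 percentage points lower from compound 1 to compound 3 (beyond the scatter) was large; likewise the step of a number 25 percentage points lower from compound 1 to compound 2 (beyond the scatter) was modest. Both steps run from a secondary amide to one without a hydrogen-bond donor and both lower the read-out, so returning to a group with one donor in compound 4 is expected to raise it.

For compound 4 the estimated step is therefore a number 24 percentage points higher from compound 3 to compound 4 (beyond the scatter), giving an expected value of 38%, with a range from 20% to 55%.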

Compound 4, a percentage reported as inhibition, in the whole organism at one dose (the size of the read-out at that dose, not a potency): 5%
Compound 4: middle estimate off by 33 percentage points, on the high side; the measured number lies below the stated range.
By their numbers in this assay, from the lowest: compounds 4, 3 and 2 (each within the scatter of the next, the first and the last beyond it); then compound 1.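

The step of a number 9 percentage points lower from compound 3 to compound 4 (within the scatter) shows that in this assay restoring the amide hydrogen does not by itself restore the read-out, and the step of a number 15 percentage points lower from compound 2 to compound 4 (beyond the scatter) sets the new secondary amide even under a compound that has no such hydrogen, so compound 4 goes against any link between that hydrogen and the read-out. The step of a number 40 percentage points lower from compound 1 to compound 4 (beyond the scatter) shows instead that this position responds to what the amide-type nitrogen carries, since cyclopropyl in place of ethyl is a single change and compound 1 stays apart from the other three compounds. No measurement in hand explains this difference between ethyl and cyclopropyl.

The compounds shown leave open whether the higher read-out belongs to ethyl alone or to open chains more widely. An n-propyl or isopropyl group on the amide-type nitrogen would speak to that, as would a methyl group at the short end.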